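Thiadiazole for benzothiazole on the lowest member of the series

A few compounds are considered here, and "the series" means these few. Any claim that something is new, unique, unknown or untested is made for them only; others in the source may bear on it.

Of the compounds shown here, three have been measured in an ADME assay on HEK-293T cells (Homo sapiens) for cytotoxicity, read by MTT assay, with a stated time of 72 h, tested at 50 uM; a higher number here means more inhibition at the concentration tested (going by the name of the read-out), a lower number less inhibition. Compound 1 `O=C(Cn1c(-c2ccccc2)cc(-c2ccccc2)c1-c1ccco1)Nc1nc2ccccc2s1` gives 89.9%. Compound 2 `CCc1nnc(NC(=O)Cn2c(-c3ccccc3)cc(-c3ccccc3)c2-c2ccco2)s1` gives 81%. Compound 3 `O=C(Cn1c(-c2ccccc2)cc(-c2ccco2)c1-c1ccco1)Nc1nc2ccccc2s1` gives 65.1%, which is the lowest of the three numbers: its distance to compound 2 and to compound 1 are both beyond the scatter, so compound 3 stands apart at the bottom of this set.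

Compound 4 `CCc1nnc(NC(=O)Cn2c(-c3ccccc3)cc(-c3ccco3)c2-c2ccco2)s1` has not been measured. The difference between compound 3 and compound 4 is 5-ethyl-1,3,4-thiadiazol-2-yl in place of 1,3-benzothiazol-2-yl on an amide-type nitrogen. Within the data shown here, one measured step bears on this change directly: the same exchange made on a phenyl-bearing core gave a number 8.9 percentage points lower from compound 1 to compound 2 (within the scatter), which lies within the scatter. The other measured step, a number 24.8 percentage points lower from compound 1 to compound 3 (beyond the scatter), concerns the furan-2-yl for phenyl change and only fixes the starting point of compound 3; it says nothing about the thiadiazole exchange itself.

On this basis the change from compound 3 to compound 4 is expected to produce at most a small decrease, a number 7.1 percentage points lower from compound 3 to compound 4 (within the scatter), and most likely a number inside the scatter of compound 3. Compound 4 is therefore estimated at 58%, with a range from 42% to 74%.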

Compound 4, a percentage reported as inhibition, at one concentration (the size of the read-out at that concentration, not a potency): 90.2%
Compound 4: middle estimate off by 32.2 percentage points, on the low side; the whole stated range lies below it.
By their numbers in this assay, from the lowest: compound 3; then compounds 2, 1 and 4 (each within the scatter of the next).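

In this assay, the exchange of 1,3-benzothiazol-2-yl for 5-ethyl-1,3,4-thiadiazol-2-yl on the amide-type nitrogen gives a number 25.1 percentage points higher from compound 3 to compound 4 (beyond the scatter), so the step seen on the core of compound 1 does not carry over to the core of compound 3: the same change on two cores in this assay, a number 8.9 percentage points lower (within the scatter) from compound 1 to compound 2 and a number 25.1 percentage points higher (beyond the scatter) from compound 3 to compound 4, 34 percentage points apart, beyond the scatter of two such steps

Read the other way, furan-2-yl in place of phenyl on an aromatic carbon gives a number 9.2 percentage points higher from compound 2 to compound 4 (within the scatter) when the thiadiazole is present, and this does not match the step in the benzothiazole pair: the same change on two cores in this assay, a number 24.8 percentage points lower (beyond the scatter) from compound 1 to compound 3 and a number 9.2 percentage points higher (within the scatter) from compound 2 to compound 4, 34 percentage points apart, beyond the scatter of two such steps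

The two places therefore do not act independently in these four compounds, and the low number of compound 3 goes with furan-2-yl and 1,3-benzothiazol-2-yl together, not with either group alone.

From the compounds shown here alone, these four compounds form a single such set at one concentration, so it remains open whether the dependence between the two places extends beyond this pairing. The compounds shown also do not tell how a carboxylic acid, an amine or a longer chain in place of the ethyl of 5-ethyl-1,3,4-thiadiazol-2-yl would behave with furan-2-yl or phenyl on the core.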